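The source may hold more compounds than are shown below. What is called first, only, known or untested is meant among the compounds shown, and "the series" means these compounds.

Among the measured compounds shown here, in a functional assay on thoracic aorta (Rattus norvegicus, strain Wistar), with a stated time of 15 min (a lower number here means that less compound is needed, a higher number that more compound is needed for the effect), compound 2 (`Cc1ccc(S(=O)(=O)NC(=O)NC(C)c2cc(Br)ccc2OCc2ccccc2)cc1`) gives 138000 nM and so holds the higher of the two numbers measured so far, while compound 1 (`Cc1ccc(S(=O)(=O)N(C)C(=O)NC(C)c2cc(Br)ccc2OCc2ccccc2)cc1`) gives 67100 nM as its only neighbour. Compound 3 (`Cc1ccc(S(=O)(=O)NC(=O)NC(C)c2cc(Br)ccc2OC(C)C)cc1`) keeps the core of compound 2 but carries isopropyl in place of benzyl on an oxygen on an aromatic ring. For the measured compounds named here, no measured step touches that oxygen. Going by the values given here, the only step available is a 2.1-fold higher number from compound 1 to compound 2 (0.31 log units; beyond the scatter) with hydrogen in place of methyl on an amide-type nitrogen; it is modest, lies at another place and gives no direction for the new change. With that modest step as the sole gauge of size, and with no direction known, no shift beyond the scatter is expected in this assay and the estimated change is a 1.3-fold lower number from compound 2 to compound 3 (0.10 log units; within the scatter) with wide uncertainty on either side. For compound 3 the estimated value is 110000 nM as a middle figure, with 35000 nM to 350000 nM as the expected range.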

Compound 3, half-maximal effective concentration: 61800 nM
Beside the measured number, compound 3's estimate is 1.8-fold (0.25 log units) above it, and the stated range covers the measured number.
By their numbers in this assay, from the lowest: compounds 3 and 1 (each within the scatter of the next); then compound 2.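

The oxygen on the aromatic ring proves to be a place that responds in this assay: replacing benzyloxy with isopropoxy gives a 2.2-fold lower number from compound 2 to compound 3 (0.35 log units; beyond the scatter), so this position, untouched by the earlier pair, now has a measured direction. The change removes the six-membered aromatic ring of benzyl and goes from 7 heavy atoms to 3, and the number still falls, so in this pair that ring is not needed for the effect to be seen. The step is modest, as is the one at the amide-type nitrogen (a 2.1-fold higher number from compound 1 to compound 2 (0.31 log units; beyond the scatter)), and no information on the cause of the new shift is available.

This single pair cannot separate the loss of the ring from the loss of carbon atoms, a question that methoxy, cyclopentyloxy or a chain ending in an amine on the same oxygen could address. It also leaves open whether methyl on the amide-type nitrogen would shift the number in the same way when isopropyl sits on the oxygen.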